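This account rests on a few compounds, and the source may have more. Where it says the series, first, only, none or still open, it means among the compounds named here.

Compound 3, `c1ccc2c(-c3coc(-c4ccncc4)n3)c[nH]c2c1`, gives 105000 nM in a functional assay on MDA-MB-231 cells (Homo sapiens) for cytotoxicity, read by MTT assay, with a stated time of 48 h; a higher number here means a weaker inhibitor, a lower number a stronger inhibitor. Among the three compounds measured, compound 3 holds the second highest number. Its nearest neighbour is compound 2, `Cc1nc(-c2c[nH]c3ccccc23)co1`, which in this assay gives 103000 nM; the gap between the two, a 1.0-fold higher number from compound 2 to compound 3 (0.01 log units; within the scatter), lies within the scatter. The furthest of the three is compound 1, `c1ccc(-c2nc(-c3c[nH]c4ccccc34)co2)cc1`, which gives 171000 nM, and the step of a 1.6-fold lower number from compound 1 to compound 3 (0.21 log units; within the scatter) also stays within the scatter.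

Compound 4, `C=Cc1nc(-c2c[nH]c3ccccc23)co1`, follows from compound 3 by a single change: vinyl in place of pyridin-4-yl on an aromatic carbon. Among the measured compounds shown here, two measured steps bear on this position of the shared core. The step of a 1.7-fold lower number from compound 1 to compound 2 (0.22 log units; within the scatter) exchanges one substituent on that carbon for another, and a 1.0-fold higher number from compound 2 to compound 3 (0.01 log units; within the scatter) does the same in a second way; neither rises beyond the scatter. For the measured compounds named here, three different groups at this carbon therefore leave the number essentially unchanged, and the vinyl in compound 4 is a fourth group at the same place, with no measured step pointing to a particular direction.

Compound 4 is therefore expected to show no step beyond the scatter, no change at the digits printed from compound 3 to compound 4 (within the scatter). The estimated value of compound 4 in this assay is 105000 nM, with a range from 50000 nM to 220000 nM.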

Compound 4, half-maximal inhibitory concentration: 103000 nM
Compound 4: middle estimate off by 1.0-fold (0.01 log units), on the high side; the range from low to high includes it.
By their numbers in this assay, from the lowest: compounds 2, 4, 3 and 1 (each within the scatter of the next).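

In this assay, replacing the pyridin-4-yl of compound 3 with vinyl removes a six-membered aromatic ring and its ring nitrogen and brings in a double bond outside aromatic rings, yet the number stays within the scatter (a 1.0-fold lower number from compound 3 to compound 4 (0.01 log units; within the scatter)). The two other new steps agree, since vinyl stands level with methyl (no change at the digits printed from compound 2 to compound 4 (within the scatter)) and also with phenyl (a 1.7-fold lower number from compound 1 to compound 4 (0.22 log units; within the scatter)), so all four groups now shown on this aromatic carbon, next to the ring nitrogen and the ring oxygen, give numbers within the scatter of one another, and the earlier compounds had not shown that a group with a double bond outside aromatic rings fits this pattern. No measurement at hand offers an account of this flat response at the position. As far as these compounds go, what a basic amine, a carboxylic acid or a longer alkyl chain would do on this carbon stays open, as none of these groups appears among the four compounds. Also open is whether any change elsewhere on the shared core would move the number beyond the scatter, since all the steps shown fall at this single carbon.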